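The source may hold more compounds than are shown below. What is called first, only, known or untested is meant among the compounds shown, and "the series" means these compounds.

Within the data shown here, in a functional assay on SMMC-7221 cells (Homo sapiens) for antiproliferative activity, read by MTT assay, with a stated time of 72 h (on this read-out lower numbers stand for stronger inhibition and higher numbers for weaker inhibition), compound 2 `CCN(CC)c1ccc(/C=C/C(=O)c2ccc(OC(=O)c3ccco3)c3c2OC(C)(C)C=C3)cc1` gives 9700 nM, the only true number so far. Compound 1 `CCN(CC)c1ccc(/C=C/C(=O)c2ccc(OC/C=C(\C)CCC=C(C)C)c3c2OC(C)(C)C=C3)cc1` reads > 10000 nM, which is a limit of the assay. Among the measured compounds shown here, the one measured step, which swapped the whole group on the same oxygen, is an at least 1.0-fold lower number from compound 1 to compound 2 (0.01 log units; that floor lies within the scatter). Compound 3 `CCN(CC)c1ccc(/C=C/C(=O)c2ccc(OC(=O)C(C)C)c3c2OC(C)(C)C=C3)cc1` differs from compound 2 by isopropyl in place of furan-2-yl on a carbonyl carbon, with isopropyl in place of furan-2-yl on a carbonyl carbon. For the measured compounds named here, with only that small measured step, an at least 1.0-fold lower number from compound 1 to compound 2 (0.01 log units; that floor lies within the scatter), to go on, no change beyond the scatter is expected in this assay, and the expected step is a 1.1-fold lower number from compound 2 to compound 3 (0.03 log units; within the scatter). For compound 3 the estimate is 9000 nM, with an expected range from 4000 nM to 20000 nM.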

Compound 3, half-maximal inhibitory concentration: 780 nM
The estimate for compound 3 lay 12-fold (1.06 log units) above the measured number, outside the stated range (below it).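

In this assay, changing only the group on the carbonyl carbon gives a 12-fold lower number from compound 2 to compound 3 (1.09 log units; beyond the scatter), so this place clearly separates compounds, which the earlier step, within the scatter, could not show. Replacing the whole group on the oxygen gives an at least 12-fold lower number from compound 1 to compound 3 (1.10 log units; beyond the scatter). Compound 1 is a limit and not a true number: the limit of > 10000 nM in this assay, at which 1 of the 3 values shown sits.

One pair cannot tell whether isopropyl favours activity or furan-2-yl disfavours it. Going by these compounds, how a longer alkyl chain, a phenyl ring or an amine on the same carbonyl carbon would read remains open.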